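Replacing the Thiophene Arm with a Hydroxyindanyl Amine

The source may report more compounds than this note shows. Statements on the series, on what has been measured and on what is new or still open speak of the compounds shown alone.

Compound 3 `CN(Cc1ccsc1)C1CCN(CCCc2c[nH]c3ccc(-n4cnnc4)cc23)CC1` gives 35 nM in an assay on CHO cells for displacement of a labelled ligand from 5-hydroxytryptamine receptor 1B (Homo sapiens) (a lower number here means a stronger inhibitor, a higher number a weaker inhibitor), the second highest of three numbers. Compound 2 `c1ccc(CNCC2CCN(CCCc3c[nH]c4ccc(-n5cnnc5)cc34)CC2)cc1` gives 28 nM, and a 1.3-fold higher number from compound 2 to compound 3 (0.10 log units; within the scatter). Compound 1 `CN(Cc1ccco1)C1CCN(CCCc2c[nH]c3ccc(-n4cnnc4)cc23)CC1` gives 89 nM, and a 2.5-fold lower number from compound 1 to compound 3 (0.41 log units; beyond the scatter). Compound 4 `O[C@@H]1Cc2ccccc2[C@H]1NC1CCN(CCCc2c[nH]c3ccc(-n4cnnc4)cc23)CC1` differs from compound 3 at the same saturated ring carbon: (2-hydroxy-2,3-dihydro-1H-inden-1-yl)amino in place of methyl((thiophen-3-yl)methyl)amino on a saturated ring carbon. Both measured steps at that carbon were modest or within the scatter, which suggests the position tolerates rather different groups, though the present change is larger than either and brings two hydrogen-bond donors not seen among the three measured compounds. A step of no more than modest size, in either direction, is therefore expected. Compound 4 is estimated at 30 nM, with a range from 8 nM to 120 nM, meaning a 1.2-fold lower number from compound 3 to compound 4 (0.07 log units; within the scatter) is expected.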

Compound 4, half-maximal inhibitory concentration: 210 nM
Compound 4: the middle estimate sits 7.0-fold (0.85 log units) below what was measured, outside the stated range (above it).
By their numbers in this assay, from the lowest: compounds 2 and 3 (each within the scatter of the next); then compound 1; then compound 4.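

Going by these compounds alone, this ring carbon accepts less than the earlier compounds suggested: with the (2-hydroxy-2,3-dihydro-1H-inden-1-yl)amino group, compound 4 is the weakest of the four, showing a 6.0-fold higher number from compound 3 to compound 4 (0.78 log units; beyond the scatter), a 7.5-fold higher number from compound 2 to compound 4 (0.88 log units; beyond the scatter) and a 2.4-fold higher number from compound 1 to compound 4 (0.37 log units; beyond the scatter). The earlier steps shown here at this carbon therefore did not mark the limit of what it accepts. No measurement at hand accounts for this loss.

As far as these compounds go, what remains open is whether the hydroxyl or the fused ring system goes with the loss, which a (2,3-dihydro-1H-inden-1-yl)amino group without the hydroxyl would help separate. From the compounds shown here alone, the other stereoisomers of the group also remain open.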